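Replacing pyridin-3-yl in compound 1

This account rests on a few compounds, and the source may have more. Where it says the series, first, only, none or still open, it means among the compounds named here.

- Compound 1 (`CCCSc1nc(N/N=C/c2cccnc2)c2nnn(Cc3ccccc3)c2n1`) gives 38100 nM
- Compound 2 (`CCCSc1nc(N/N=C(\C)c2ccccc2O)c2nnn(Cc3cccc(Cl)c3)c2n1`) gives 6500 nM

In a functional assay on MGC-803 cells (Homo sapiens) for antiproliferative activity, read by MTT assay, with a stated time of 72 h (a lower number here means a stronger inhibitor, a higher number a weaker inhibitor), compound 1 gives 38100 nM as the higher of the two numbers, and compound 2 lies lower by a gap beyond the scatter. Compound 3 (`CCCSc1nc(N/N=C/c2ccc(N(C)C)cc2)c2nnn(Cc3ccccc3)c2n1`) has not yet been measured. It carries 4-(dimethylamino)phenyl in place of pyridin-3-yl on a carbon with a double bond to nitrogen. Among the compounds with values here, no measured step isolates this change, and compound 2 (6500 nM) differs in more than one place, so it is only a loose guide. A moderate step towards a lower number is expected in this assay (a 2.2-fold lower number from compound 1 to compound 3 (0.35 log units; beyond the scatter)). Compound 3 is estimated at 17000 nM (between 5000 nM and 50000 nM).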

Compound 3, half-maximal inhibitory concentration: 13100 nM
Beside the measured number, compound 3's estimate is 1.3-fold (0.11 log units) above it, and the stated range covers the measured number.
By their numbers in this assay, from the lowest: compounds 2 and 3 (each within the scatter of the next); then compound 1.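

In this assay, within the data shown here, the swap of pyridin-3-yl for 4-(dimethylamino)phenyl on a carbon with a double bond to nitrogen gives a 2.9-fold lower number from compound 1 to compound 3 (0.46 log units; beyond the scatter), the only change at this position seen on its own. It shows that this position responds to the aromatic group it carries, although the step is modest. Nothing measured here explains the shift. The compounds shown leave open how a morpholine or a carboxylic acid in place of the dimethylamino group would read, and whether the step holds with 3-chlorobenzyl in place of the benzyl group.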